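Working notes: from compound 3 to compound 4

A few compounds are considered here, and "the series" means these few. Any claim that something is new, unique, unknown or untested is made for them only; others in the source may bear on it.

Measured so far in an ADME assay on liver for metabolic stability, with Liver microsome (Homo sapiens) as the target, read by LC-MS, using microsomes; a higher number here means faster removal of the compound, a lower number slower removal:
- compound 1 `CCCC[C@@H](O)C(=O)N1C[C@H]2C[C@H]2[C@H]1C(=O)NCc1cc(Cl)ccc1-n1cnnn1` gives 32 mL.min-1.g-1
- compound 2 `COC(C)(C)[C@@H](O)C(=O)N1C[C@H]2C[C@H]2[C@H]1C(=O)NCc1cc(Cl)ccc1-n1cnnn1` gives 23 mL.min-1.g-1
- compound 3 `CC(C)(C)[C@@H](O)C(=O)N1C[C@H]2C[C@H]2[C@H]1C(=O)NCc1cc(Cl)ccc1-n1cnnn1` gives 22 mL.min-1.g-1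

Compound 3 does not stand apart on these numbers: at 22 mL.min-1.g-1 it lies within the scatter of both compound 1 and compound 2.

The next structure is compound 4 `CC1(C[C@@H](O)C(=O)N2C[C@H]3C[C@H]3[C@H]2C(=O)NCc2cc(Cl)ccc2-n2cnnn2)CC1`, which has (1-methylcyclopropyl)methyl in place of tert-butyl on the shared core, the change being (1-methylcyclopropyl)methyl in place of tert-butyl on a saturated chain carbon bound to a carbonyl carbon and an oxygen on a saturated carbon in full.

Among the measured compounds shown here, three measured steps concern this group. The step of a 1.5-fold lower number from compound 1 to compound 3 (0.16 log units; within the scatter) is within the scatter, as are the step of a 1.4-fold lower number from compound 1 to compound 2 (0.14 log units; within the scatter) and the step of a 1.0-fold lower number from compound 2 to compound 3 (0.02 log units; within the scatter) in this series. Butyl, tert-butyl and 1-methoxy-1-methylethyl therefore cannot be separated in this assay on these data. For the measured compounds named here, no measured compound has a ring in this group, so that part of the change remains untested.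

An estimated step of a 1.3-fold higher number from compound 3 to compound 4 (0.12 log units; within the scatter) is expected, slightly upward and no larger than the scatter. The upward lean is tentative, taken from compound 1 at 32 mL.min-1.g-1 as the other measured carbon-only group. For compound 4 the expected value is 29 mL.min-1.g-1, with an estimated range from 16 mL.min-1.g-1 to 50 mL.min-1.g-1 in this assay.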

Compound 4, intrinsic clearance in microsomes: 12 mL.min-1.g-1
Compound 4: the middle estimate sits 2.4-fold (0.38 log units) above what was measured; measured number below the stated range.
By their numbers in this assay, from the lowest: compounds 4, 3, 2 and 1 (each within the scatter of the next, the first and the last beyond it).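

In this assay this position, the saturated chain carbon bound to a carbonyl carbon and an oxygen on a saturated carbon, now shows its first step beyond the scatter, a modest one, with 1-methylcyclopropyl in place of propyl (a 2.7-fold lower number from compound 1 to compound 4 (0.43 log units; beyond the scatter)). Among the compounds shown here, the other two steps stay within the scatter (a 1.8-fold lower number from compound 3 to compound 4 (0.26 log units; within the scatter)) (a 1.9-fold lower number from compound 2 to compound 4 (0.28 log units; within the scatter)), so (1-methylcyclopropyl)methyl cannot be separated from tert-butyl or 1-methoxy-1-methylethyl, and the separation holds only against the butyl of compound 1, while a three-membered ring of carbon only in this group brings no step upward against any of the three earlier compounds. Nothing available on this series bears on what lies behind the step from butyl.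

The compounds shown leave open how much of that step belongs to the ring itself, since compound 4 is the only ring-bearing group here and no open-chain group of the same five carbons stands beside it. Also open, going by these compounds, is how this position behaves with an amine, a carboxylic acid or a six-membered carbon ring in place of these groups.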